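Nitro in place of methoxy: a second instance

The source may hold more compounds than are shown below. What is called first, only, known or untested is meant among the compounds shown, and "the series" means these compounds.

Compound 1, `COc1ccc(-c2c(CNC(C)(C)C)c(C(=O)O)nn2-c2ccccc2)cc1`. In a functional assay on OVCAR-3 cells (Homo sapiens) for inhibition, read by sulforhodamine B assay, with a stated time of 48 h (on this read-out higher numbers stand for weaker inhibition of growth and lower numbers for stronger inhibition of growth), compound 1 shows only the assay limit, > 659000 nM.
Compound 2, `CC(C)(C)NCc1c(C(=O)O)nn(-c2ccccc2)c1-c1ccc([N+](=O)[O-])cc1`. Compound 2 likewise shows only a limit in this assay, > 634000 nM.
Compound 3, `COc1ccc(-c2c(CNC(C)(C)C)c(C(=O)O)nn2-c2ccc(Cl)cc2)cc1`. In this assay compound 3 gives 121000 nM.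

The change from compound 1 to compound 2 is nitro in place of methoxy on an aromatic carbon. Its step, a step that the two limits leave unreadable from compound 1 to compound 2, cannot be read because both values sit at a limit, the limit of > 659000 nM in this assay, at which 1 of the 3 values shown sits, and (the limit of > 634000 nM in this assay, at which 1 of the 3 values shown sits). The cores of compound 1 and compound 3 differ by chloro in place of hydrogen on an aromatic carbon, which gave an at least 5.4-fold lower number from compound 1 to compound 3 (0.73 log units; beyond the scatter).

Compound 4, `CC(C)(C)NCc1c(C(=O)O)nn(-c2ccc(Cl)cc2)c1-c1ccc([N+](=O)[O-])cc1`, differs from compound 3 by nitro in place of methoxy on an aromatic carbon, the same change as from compound 1 to compound 2, at a place described in the same words. The earlier instance gives no readable size, so the expectation for compound 4 rests on compound 3 alone: the step is expected to be small, a 1.3-fold higher number from compound 3 to compound 4 (0.12 log units; within the scatter). Compound 4 is therefore estimated at 160000 nM, between 50000 nM and 500000 nM.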

Compound 4, concentration for 50% growth inhibition: 162000 nM
Beside the measured number, compound 4's estimate is 1.0-fold (0.01 log units) below it, within the range that was stated.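

In this assay, nitro in place of methoxy on the core of compound 3 gives a 1.3-fold higher number from compound 3 to compound 4 (0.13 log units; within the scatter), so the two groups are not told apart on this core. The same change from compound 1 to compound 2 cannot be read, as both values are limits, so this is one readable instance and does not show that the change carries from one core to another. Chloro in place of hydrogen gives an at least 3.9-fold lower number from compound 2 to compound 4 (0.59 log units; beyond the scatter), and the two instances compare as follows: the same change on two cores in this assay, an at least 5.4-fold lower number (0.73 log units; beyond the scatter) from compound 1 to compound 3 and an at least 3.9-fold lower number (0.59 log units; beyond the scatter) from compound 2 to compound 4; the limit leaves it open whether they differ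

Still open, on these data alone, is whether an amine or a nitrile in place of methoxy or nitro would give a similar number. Also open, as far as these compounds go, is how an ester in place of the carboxylic acid, or fluoro in place of chloro, would read.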